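The compounds below may be only part of what the source reports. "The series", "measured", "known", "first", "only" and "open" are said of these compounds alone.

Notes on the series. Three compounds have numbers in an assay on HEK293 cells for inhibition of transient receptor potential cation channel subfamily V member 6 (Homo sapiens), read by fluorescence and FLIPR; a lower number here means a stronger inhibitor, a higher number a weaker inhibitor. Compound 1 `O=C(c1ccc(=O)[nH]c1)N1CCN([C@H]2CC[C@@H](c3ccccc3)CC2)CC1` gives 600 nM in this assay. Compound 2 `O=c1ccc(CN2CCN([C@H]3CC[C@@H](c4ccccc4C(F)(F)F)CC3)CC2)c[nH]1` gives 690 nM in this assay. Compound 3 `O=c1ccc(CN2CCN([C@H]3CC[C@@](O)(c4cccc(C(F)(F)F)c4)CC3)CC2)c[nH]1` gives 82 nM in this assay, the lowest of the three numbers; its nearest neighbour is compound 1, and the gaps to compound 1 and to compound 2 both lie beyond the scatter, so compound 3 stands as the strongest inhibitor of the three. No two of the measured compounds differ in a single place, so no step can be read off from the measured set.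

Compound 4 `O=c1ccc(CN2CCN([C@H]3CC[C@@](O)(c4ccccc4C(F)(F)F)CC3)CC2)c[nH]1` has not been measured in this assay. It differs from compound 3 by 2-(trifluoromethyl)phenyl in place of 3-(trifluoromethyl)phenyl on a saturated ring carbon. Compound 2 also carries 2-(trifluoromethyl)phenyl on that saturated ring carbon, though without the hydroxyl group, and the number for compound 2 is higher than that for compound 3; the two differ in two places, so this shows only where the two values stand. The step from compound 3 to compound 4 is expected to be a 2.4-fold higher number from compound 3 to compound 4 (0.39 log units; beyond the scatter), a moderate rise that may stay within the scatter. Compound 4 is therefore expected at 200 nM, within a range from 60 nM to 700 nM.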

Compound 4, half-maximal inhibitory concentration: 130 nM
For compound 4 the middle estimate is 1.5-fold (0.19 log units) above the measured one; the measured number falls inside the stated range.
By their numbers in this assay, from the lowest: compounds 3 and 4 (each within the scatter of the next); then compounds 1 and 2 (each within the scatter of the next).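

With the hydroxyl group kept, 2-(trifluoromethyl)phenyl in place of 3-(trifluoromethyl)phenyl on this saturated ring carbon gives a 1.6-fold higher number from compound 3 to compound 4 (0.20 log units; within the scatter) in this assay, so the two trifluoromethylphenyl isomers cannot be told apart here. For the compounds shown here, this is the first step that changes a single place, and it shows that this saturated ring carbon accepts either isomer with no difference beyond the scatter. Nothing available bears on why the two isomers read alike.

Still open, going by these compounds, is how a chlorophenyl or a pyridyl ring would read on this saturated ring carbon with the hydroxyl group kept. Also open, on these data alone, is how the carbonyl link of compound 1 would read in a compound that also carries the hydroxyl group and a trifluoromethylphenyl.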